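The source may report more compounds than this note shows. Statements on the series, on what has been measured and on what is new or still open speak of the compounds shown alone.

Measured compounds:
- compound 1, `CC(C)(C)c1ccc(NC(=O)c2ccc(-c3ccccn3)cc2)cc1`, 11 nM
- compound 2, `CCCNc1cccnc1-c1ccc(C(=O)Nc2ccc(C(C)(C)C)cc2)cc1`, 158 nM

Within the data shown here, in a functional assay for antagonist activity at transient receptor potential cation channel subfamily V member 1 (Homo sapiens), read by FLIPR (a lower number here means a stronger inhibitor, a higher number a weaker inhibitor), compound 2 gives the higher of the two numbers, and the only measured step that leads to it, a 14-fold higher number from compound 1 to compound 2 (1.16 log units; beyond the scatter), shows that putting the propylamino group onto the ring carbon of compound 1 weakened the inhibitor markedly. Compound 3, `CC(C)(C)c1ccc(NC(=O)c2ccc(-c3ncccc3NS(C)(=O)=O)cc2)cc1`, has not yet been measured. It differs from compound 2 in one place: methylsulfonyl in place of propyl on a nitrogen on an aromatic ring. Among the measured compounds shown here, only one measured step bears on this change, and it is indirect: the step from compound 1 to compound 2 tells how the propylamino group itself behaves, but nothing measured shows how the methanesulfonamido group on the same ring carbon behaves. The direction of the expected step is therefore open. Since the propyl group on the nitrogen is removed, some of the loss seen in a 14-fold higher number from compound 1 to compound 2 (1.16 log units; beyond the scatter) might be recovered, but a new group enters in its place, so the expectation stays close to compound 2 with a wide range. Compound 3 is estimated at 70 nM, between 15 nM and 300 nM, which means an expected step of a 2.3-fold lower number from compound 2 to compound 3 (0.35 log units; beyond the scatter).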

Compound 3, half-maximal inhibitory concentration: 152 nM
Compound 3: middle estimate off by 2.2-fold (0.34 log units), on the low side; the range from low to high includes it.
By their numbers in this assay, from the lowest: compound 1; then compounds 3 and 2 (each within the scatter of the next).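

In this assay, replacing propyl with methylsulfonyl on this nitrogen gives a 1.0-fold lower number from compound 2 to compound 3 (0.02 log units; within the scatter) and leaves the two compounds indistinguishable, even though methylsulfonyl brings sulfur and two oxygens, counted as hydrogen-bond acceptors, where propyl has none. The earlier compounds shown here showed the loss for propylamino alone, whereas a 14-fold higher number from compound 1 to compound 3 (1.14 log units; beyond the scatter) is a large step in the same direction as a 14-fold higher number from compound 1 to compound 2 (1.16 log units; beyond the scatter) and shows that the loss is not unique to propylamino. Among the compounds shown, both groups on this aromatic carbon give a higher number than hydrogen, and no compound goes against this, but nothing here gives a measured reason for the pattern or for the match between the two groups.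

The compounds shown leave open whether only hydrogen keeps the low number seen for compound 1, or whether a plain amine or a single methyl on this carbon would also stay close to it. As far as these compounds go, it is also open whether a longer chain or an acetyl group on the nitrogen would stay level with compound 2 and compound 3 or move away from them.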